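The compounds below may be only part of what the source reports. "The series", "measured", "known", "first", "only" and "open" are said of these compounds alone.

Compound 2 `c1ccc(-c2cnoc2)c(NCC2=NCCN2)c1` carries a 1,2-oxazol-4-yl group on an aromatic carbon of the shared core. In a functional assay for activation of Alpha-1B adrenergic receptor (Homo sapiens), read by calcium flux (on this read-out lower numbers stand for an effect already at smaller amounts and higher numbers for an effect only at larger amounts of compound), compound 2 gives only a limit, < 100000 nM, and no number. Its two measured neighbours are compound 1 `Cc1nc(-c2ccccc2NCC2=NCCN2)cs1`, which in this assay gives 69.2 nM, and compound 3 `Cc1nc(-c2ccccc2NCC2=NCCN2)no1`, which gives 676 nM. For the measured compounds named here, the one readable step, a 9.8-fold higher number from compound 1 to compound 3 (0.99 log units; beyond the scatter), shows that exchanging one five-membered group for another moves the read-out modestly; the steps a step that the limit leaves unreadable from compound 1 to compound 2 and a step that the limit leaves unreadable from compound 2 to compound 3 cannot be sized because of the limit (the limit of < 100000 nM in this assay, at which 1 of the 3 values shown sits).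

Compound 4 `CCO/N=C(\C)c1ccccc1NCC1=NCCN1` has not been measured. It differs from compound 2 in that (a group of 6 heavy atoms (4 carbon, 1 nitrogen, 1 oxygen; no ring) in place of a group of 5 heavy atoms (3 carbon, 1 nitrogen, 1 oxygen; one five-membered aromatic ring with 2 hetero atoms), on an aromatic carbon). Going by the values given here, no measured step covers the exchange of a ring for a group with no ring, so the expectation rests on the spread between compound 1 and compound 3 and on the limit of compound 2. Compound 4 is expected to give an estimated 2000 nM, with a range from 200 nM to 20000 nM. That estimate means an expected step that the limit leaves unreadable from compound 2 to compound 4.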

Compound 4, half-maximal effective concentration: < 5020 nM
Compound 4 ended at the assay's limit (the forecaster's own chance of this, stated with the estimate: 35%); the middle value lies beyond the limit too.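

For the compounds shown here, no step from compound 1, compound 2 or compound 3 to compound 4 can be read in this assay. Compound 4 gives only a limit, < 5020 nM. The compounds shown leave open how far a group with no ring, in place of a five-membered aromatic ring, moves the read-out.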